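Benzamide series against histone deacetylase 8: working notes

A few compounds are considered here, and "the series" means these few. Any claim that something is new, unique, unknown or untested is made for them only; others in the source may bear on it.

Measured compounds:
compound 1 `Nc1cc2ccccc2cc1NC(=O)c1ccc(CNc2nccc(-c3cccnc3)n2)cc1` — > 20000 nM
compound 2 `Nc1ccccc1NC(=O)c1ccc(CNC2=N[C@H](Cc3ccccc3)CS2)cc1` — 12700 nM

In an assay for inhibition of histone deacetylase 8 (Homo sapiens), read by fluorescence, with stated times of 15 min and 60 min (on this read-out higher numbers stand for weaker inhibition and lower numbers for stronger inhibition), compound 1 gives > 20000 nM; this is a limit of the assay and not a number, so compound 1 stands only at the limit of > 20000 nM in this assay, at which 1 of the 2 values shown sits, and nothing finer is known about it. Going by the values given here, compound 2 carries a different aryl group on the amide-type nitrogen and a different group on the benzylic amine, so no single step joins it to compound 1; in this assay compound 2 gives 12700 nM, and both values sit at the weak end of the read-out.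

Among the compounds with values here, compound 3 `Nc1cc(Br)ccc1NC(=O)c1ccc(CNc2nccc(-c3cccnc3)n2)cc1` is the one change from compound 1 that is followed here: a group of 8 heavy atoms (6 carbon, 1 nitrogen, 1 bromine; one six-membered aromatic ring of carbon only) in place of a group of 11 heavy atoms (10 carbon, 1 nitrogen; 2 six-membered aromatic rings of carbon only), on an amide-type nitrogen. Within the data shown here, no measured pair isolates a change of this kind, so the expectation rests on the two weak values already in hand. The step from compound 1 to compound 3 in this assay is expected to be small or none beyond the scatter, and a limit rather than a number is about as likely as not. Compound 3 is expected to give 15000 nM in this assay, within 4000 nM to 40000 nM. The expected step is an at least 1.3-fold lower number from compound 1 to compound 3 (0.12 log units; that floor lies within the scatter).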

Compound 3, half-maximal inhibitory concentration: > 20000 nM
Compound 3 gave a limit, no number; the forecaster's own chance of this, stated with the estimate: 45%; middle value at least 1.3-fold (0.12 log units) from the limit.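

Compound 1 and compound 3 both stand at a limit, not a number, in this assay, so no step between them can be read: the limit of > 20000 nM in this assay, at which 2 of the 3 values shown sit.

The compounds shown leave open whether placing 2-amino-4-bromophenyl on the amide-type nitrogen changes inhibition in this assay at all, and where compound 1 and compound 3 truly stand.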